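The compounds below may be only part of what the source reports. "The series", "measured", "known", "first", "only" and "open" are said of these compounds alone.

Compound 1 `COc1ccc(/C=C/C(=O)c2ccccc2-c2ccc(OC)c(OC)c2)cc1OC`: 3200 nM
Compound 2 `COc1ccc(/C=C/C(=O)c2ccccc2-c2ccc(F)nc2)cc1`: 290 nM

Both values come from a functional assay on HepG2 cells (Homo sapiens) for antiproliferative activity, read by sulforhodamine B assay, with a stated time of 48 h; on this read-out lower numbers stand for stronger inhibition and higher numbers for weaker inhibition. Compound 2 holds the lower of the two numbers, so it is the stronger inhibitor here, and its gap to compound 1 lies beyond the usual scatter of repeated measurements. Among the compounds with values here, with only two compounds measured, this ranking says little on its own.

The next compound, compound 3 `COc1ccc(/C=C/C(=O)c2ccccc2-c2ccc(F)nc2)cc1OC`, is built from compound 2 by a single change: methoxy in place of hydrogen on an aromatic carbon, ortho to a methoxy group (methoxy in place of hydrogen on an aromatic carbon). Within the data shown here, no measured pair differs in just one place, so the data give no direct measure of this change. Compound 1 also carries a methoxy ortho to a methoxy group and gives 3200 nM, which is only a weak hint towards a higher number. A modest weakening is therefore expected, and the estimated step is a 1.6-fold higher number from compound 2 to compound 3 (0.19 log units; within the scatter). For compound 3 the expected value is 450 nM, with an estimated range from 130 nM to 1500 nM.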

Compound 3, half-maximal inhibitory concentration: 1000 nM
Compound 3: middle estimate off by 2.2-fold (0.35 log units), on the low side; measured number inside the range.
By their numbers in this assay, from the lowest: compound 2; then compound 3; then compound 1.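

In this assay, the methoxy on the aromatic carbon, ortho to a methoxy group, now has a direct measure: a 3.4-fold higher number from compound 2 to compound 3 (0.54 log units; beyond the scatter). Adding this one group therefore weakens inhibition by a margin beyond the scatter, which the first two compounds, differing in more than one place, could not show on their own. Compound 3 also links to compound 1 through a single change at a different place, 6-fluoropyridin-3-yl in place of 3,4-dimethoxyphenyl, and this gives a 3.2-fold lower number from compound 1 to compound 3 (0.51 log units; beyond the scatter), so inhibition here responds to both places in the molecule. No measurement shown here explains either step.

As far as these compounds go, it remains open whether a hydroxyl, a fluorine or an amine on this same aromatic carbon would give a lower or a higher number than the methoxy does. From the compounds shown here alone, it is also open whether removing this methoxy from compound 1 would give a step of similar size, which would show whether the effect holds with 3,4-dimethoxyphenyl in place of 6-fluoropyridin-3-yl.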